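This account rests on a few compounds, and the source may have more. Where it says the series, first, only, none or still open, it means among the compounds named here.

Compound 1 `N#Cc1c(Cl)c(Cl)c(C(C(=O)c2ccccc2)=C2NCCN2)c(C#N)c1Cl`: 10.2 ug/mL
Compound 2 `N#Cc1c(F)c(Cl)c(C(C(=O)c2ccccc2)=C2NCCN2)c(C#N)c1F`: 32.6 ug/mL
Compound 3 `Cc1ccc(C(=O)C(=C2NCCN2)c2c(F)c(F)c(C#N)c(F)c2C#N)cc1`: 29.2 ug/mL

In a functional assay on HepG2 cells (Homo sapiens) for antiproliferative activity, read by MTT assay (on this read-out lower numbers stand for stronger inhibition and higher numbers for weaker inhibition), compound 1 gives 10.2 ug/mL, the lowest of the three numbers, and its gaps to compound 2 and compound 3 both lie beyond the scatter. Compound 4 `COc1ccc(C(=O)C(=C2NCCN2)c2c(Cl)c(Cl)c(C#N)c(Cl)c2C#N)cc1` keeps the core of compound 1 and differs in one place, with methoxy in place of hydrogen on an aromatic carbon, phenyl becoming 4-methoxyphenyl: methoxy in place of hydrogen on an aromatic carbon. Among the compounds with values here, no measured pair shows this change on its own, so the expectation is weakly founded. No step beyond the scatter is expected in this assay. The estimated step is a 1.2-fold higher number from compound 1 to compound 4 (0.07 log units; within the scatter). For compound 4 the expected value is 12 ug/mL, with an estimated range of 5 ug/mL to 30 ug/mL.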

Compound 4, half-maximal inhibitory concentration: 10.8 ug/mL
For compound 4 the middle estimate is 1.1-fold (0.05 log units) above the measured one; measured number inside the range.
By their numbers in this assay, from the lowest: compounds 1 and 4 (each within the scatter of the next); then compounds 3 and 2 (each within the scatter of the next).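

In this assay the change from phenyl to 4-methoxyphenyl gives a 1.1-fold higher number from compound 1 to compound 4 (0.02 log units; within the scatter) and so stays within the scatter. Within the data shown here, this shows that this aromatic carbon, para to a large group, takes methoxy in place of hydrogen without a step beyond the scatter, which no earlier pair could show. No measurement shown here gives a reason for this result. The compounds shown leave open how an amine or a carboxylic acid would read at this place, and whether a longer chain such as butoxy would also stay within the scatter.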